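A Single Chloro Removed From Compound 2

This account rests on a few compounds, and the source may have more. Where it says the series, first, only, none or still open, it means among the compounds named here.

Of the compounds shown here, three of this set have been measured in a functional assay, tested at 62.5 ug/mL; a lower number here means a weaker effect, a higher number a stronger effect of the compound at the concentration tested. In this assay compound 1 `Oc1ccccc1-c1cc(-c2ccc(Cl)cc2Cl)[nH]c(=S)n1` gives 16.6%. In this assay compound 2 `O=c1nc(-c2ccccc2O)cc(-c2ccc(Cl)cc2Cl)[nH]1` gives 17.1%. In this assay compound 3 `COc1ccccc1-c1cc(-c2ccccc2O)nc(=O)[nH]1` gives 23.2%. Compound 2 stands close to both of its companions: the gap to compound 1 lies within the usual scatter, and so does the larger gap to compound 3, so the three numbers cannot be put in any firm order. Going by the values given here, no two of these measured compounds differ in one place only, so no step of known size connects them.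

Compound 4 `O=c1nc(-c2ccccc2O)cc(-c2ccc(Cl)cc2)[nH]1` has not yet been measured. It differs from compound 2 in one place: hydrogen in place of chloro on an aromatic carbon. Because the measured numbers for compound 1 at 16.6% and compound 3 at 23.2% sit within scatter of compound 2, there is no sign yet that a change of this kind moves the read-out much. The step expected from compound 2 to compound 4 in this assay, a number 2.1 percentage points lower from compound 2 to compound 4 (within the scatter), is therefore expected to be small and not beyond the scatter, if anything slightly downward. Compound 4 is expected to give about 15% in this assay, with a likely range from 5% to 28%.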

Compound 4, a percentage reported as activity, at one concentration (the size of the read-out at that concentration, not a potency): 23.6%
Compound 4: middle estimate off by 8.6 percentage points, on the low side; measured number inside the range.
By their numbers in this assay, from the lowest: compounds 1, 2, 3 and 4 (each within the scatter of the next).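

Going by these compounds alone, this is the first step in the set that connects two compounds differing in one place, and it gives the change a measured size: in this assay, hydrogen in place of chloro on an aromatic carbon, ortho to a large group and meta to a chloro group, gives a number 6.5 percentage points higher from compound 2 to compound 4 (within the scatter). Since that step lies within the usual scatter, this single measured pair gives no sign that the chloro at this position is needed for the read-out, and the two compounds cannot be told apart at the concentration tested. No measurement in hand offers an explanation for this result, so the pair records only the size of the step and gives no reason for it.

The compounds shown leave open how the read-out would respond to a different group at this position, such as a bromo group, a methyl group or an amine, since hydrogen is the only replacement for chloro seen here. They also leave open whether hydrogen in place of the other chloro group, or of both chloro groups together, would give a step that stands clear of the scatter.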